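The source may hold more compounds than are shown below. What is called first, only, known or untested is meant among the compounds shown, and "the series" means these compounds.

Measured so far in a functional assay on HUVEC cells (Homo sapiens) for inhibition, read by MTT assay, with a stated time of 24 h, tested at 10 uM; on this read-out higher numbers stand for more inhibition of growth at the one concentration tested and lower numbers for less inhibition of growth:
Compound 1 `COc1cc2ccc(=O)oc2cc1OCC(=O)c1ccc(Cl)c(Cl)c1`, giving 0%
Compound 2 `COc1cc2ccc(=O)oc2cc1OCC(O)CN1CCCCC1`, giving 31.4%

Compound 2 stands highest of the two numbers in this assay; its nearest neighbour is compound 1, whose value lies lower by a gap beyond the usual scatter. The two compounds differ in more than one place, so nothing is said here of what a single change would do between them.

Compound 3 `CCN(CC)CC(O)COc1cc2oc(=O)ccc2cc1OC` is not yet measured in this assay. It differs from compound 2 in one place: diethylamino in place of piperidin-1-yl on a saturated chain carbon, two bonds along the chain from an oxygen on a saturated carbon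

Among the measured compounds shown here, the change swaps one amine for another of nearly the same size at the same place on the chain, and nothing among the measured compounds shows what such a swap does here. The account therefore expects a step of a number 3.4 percentage points lower from compound 2 to compound 3 (within the scatter), that is, none beyond the scatter. Compound 3 is expected to give about 28%, within a range of 10% to 45%.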

Compound 3, percent growth inhibition at one concentration: 0.5%
The estimate for compound 3 lay 27.5 percentage points above the measured number, and the stated range ends above it.
By their numbers in this assay, from the lowest: compounds 1 and 3 (each within the scatter of the next); then compound 2.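

In this assay, putting diethylamino in place of piperidin-1-yl on a saturated chain carbon, two bonds along the chain from an oxygen on a saturated carbon, gives a number 30.9 percentage points lower from compound 2 to compound 3 (beyond the scatter). This shows that inhibition of growth at the one concentration tested depends on which amine stands at this place, although the two groups match in their counts of hydrogen-bond donors and acceptors and only one of them has a ring. No measurement shown here accounts for the step.

This single pair cannot separate the presence of the ring from the other differences between the two amines. As far as these compounds go, a pyrrolidine, a morpholine or a dimethylamino group at the same place remains open, as does whether the step would hold at other concentrations.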